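The source may hold more compounds than are shown below. What is called first, only, known or untested is meant among the compounds shown, and "the series" means these compounds.

Of the compounds shown here, two have so far been measured in an ADME assay on microsomes from liver (Mus musculus) for metabolic stability, read by LC-MS, with a stated time of 30 min, tested at 1 uM; a lower number here means that less of the compound is left, a higher number that more of the compound is left. Compound 1, with the structure `O=C(NCc1ccc(S(=O)(=O)N2CCCCC2)cc1)c1ccn2cncc2c1`, gives 1% in this assay, the lowest of the two numbers recorded. Compound 2, with the structure `O=C(NCc1ccc(S(=O)(=O)c2ccccc2)cc1)c1ccc2ccncc2c1`, gives 3.3% in this assay. The two values lie within the usual scatter of each other, so the numbers show only that very little of either compound survives the incubation, and nothing separates them.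

Compound 3, with the structure `O=C(NCc1ccc(S(=O)(=O)N2CCCCC2)cc1)c1cnc2nccn2c1`, has not yet been measured. It differs from compound 1 in one place: a group of 9 heavy atoms (6 carbon, 3 nitrogen; one five-membered aromatic ring with 2 hetero atoms, one six-membered aromatic ring with 2 hetero atoms) in place of a group of 9 heavy atoms (7 carbon, 2 nitrogen; one five-membered aromatic ring with 2 hetero atoms, one six-membered aromatic ring with 1 hetero atom), on a carbonyl carbon. Among the compounds with values here, no step between two measured compounds is known here, so there is no measured change in this assay to lean on, and the expectation for compound 3 rests on compound 1 alone. Both measured compounds are almost fully consumed, and a change of this kind gives no ground to expect a step beyond the scatter; the step from compound 1 to compound 3 is estimated as a number 4 percentage points higher from compound 1 to compound 3 (within the scatter). Compound 3 is therefore expected to give 5% in this assay, with a range from 1% to 20%.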

Compound 3, percent of the compound remaining: 0.28%
Compound 3: the middle estimate sits 4.7 percentage points above what was measured, outside the stated range (below it).
By their numbers in this assay, from the lowest: compounds 3, 1 and 2 (each within the scatter of the next).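

Within the data shown here, the step of a number 0.7 percentage points lower from compound 1 to compound 3 (within the scatter) in this assay is the first measured change at this carbonyl carbon, and it gives a direct reading of this position rather than a comparison of two unrelated compounds. Putting a group with a six-membered aromatic ring with 2 hetero atoms in place of one with a six-membered aromatic ring with 1 hetero atom, which also adds a hydrogen-bond acceptor by the count, leaves the compound almost entirely consumed, as compound 3 gives 0.28%. No measurement here bears on why this exchange leaves the result within the scatter, so the reason remains unknown.

Among these compounds, with so little left of compound 1 and compound 3, this assay has almost no room to show a further loss, so the step says only that this change brings no visible gain in survival, and leaves open whether any group on this carbonyl carbon, such as a plain phenyl ring or a ring carrying an amine, would keep more of the compound intact. Also open, going by these compounds, is whether a change elsewhere, such as a morpholine in place of the group on the sulfonyl, would matter more than this one.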